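Cyclic sulfamide series: cytotoxicity on HEL cells

The source may hold more compounds than are shown below. What is called first, only, known or untested is meant among the compounds shown, and "the series" means these compounds.

Measured so far:
compound 1, `O=C1c2ccccc2NS(=O)(=O)N1COCCO`, in a functional assay on HEL cells (Homo sapiens) for cytotoxicity (on this read-out lower numbers stand for higher toxicity in this test and higher numbers for lower toxicity in this test), gives > 50 ug/mL, a limit of the assay.
compound 2, `O=C1c2ccccc2N(Cc2ccccc2)S(=O)(=O)N1COCc1ccccc1`, gives 20 ug/mL.
compound 3, `C#CCOCN1C(=O)c2ccccc2NS1(=O)=O`, gives > 50 ug/mL, again a limit.

Compound 3 therefore stands at the limit; (the limit of > 50 ug/mL in this assay, at which 2 of the 3 values shown sit). Going by the values given here, compound 2 is the only compound with a numbered value. Among the compounds with values here, the single measured step, a step that the two limits leave unreadable from compound 1 to compound 3, has limits at both ends and its size stays unread.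

Compound 4, `O=C1c2ccccc2NS(=O)(=O)N1COCc1ccccc1`, differs from compound 3 by phenyl in place of ethynyl on a saturated chain carbon bound to an oxygen on a saturated carbon. No readable measured step bears on this change. Compound 2 also carries a benzyl on a saturated chain carbon bound to an oxygen on a saturated carbon, but differs from compound 4 in a further place, so only its value is informative: compound 2 gives 20 ug/mL. Two of three values sit at the limit, and the benzyl alone need not pull compound 4 down to where compound 2 stands.

The step of a number no higher from compound 3 to compound 4 (the limit leaves the size open) is expected to be small or unreadable, most likely ending at the limit. For compound 4 the estimate is 50 ug/mL, with a range from 20 ug/mL to 150 ug/mL.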

Compound 4, minimum cytotoxic concentration: > 50 ug/mL
Compound 4: no number, only a limit; the forecaster's own chance of this, stated with the estimate: 55%; the middle value lies on the limit itself.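

Compound 4 gives > 50 ug/mL in this assay, a limit, so phenyl at this place on a saturated chain carbon bound to an oxygen on a saturated carbon brings no numbered value on its own. Going by these compounds alone, with that side chain held constant, hydrogen in place of benzyl on a sulfonamide nitrogen in a ring gives an at least 2.5-fold higher number from compound 2 to compound 4 (0.39 log units; beyond the scatter), which ties the only numbered value to the benzyl on that ring nitrogen, not to the side chain. The steps among compound 1, compound 3 and compound 4 cannot be read, and compound 4 adds to the values sitting at the ceiling of the read-out: the limit of > 50 ug/mL in this assay, at which 3 of the 4 values shown sit.

As far as these compounds go, whether a benzyl on the ring nitrogen gives a numbered value with the side chains of compound 1 and compound 3 stays open, as does whether a smaller group there, such as methyl, does the same. Also open, from the compounds shown here alone, is whether an amine or a carboxylic acid on the phenyl of the side chain would leave the value at the limit.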